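Catechol in Place of Chlorophenyl on the Hydrazone Arm

A few compounds are considered here, and "the series" means these few. Any claim that something is new, unique, unknown or untested is made for them only; others in the source may bear on it.

Three compounds sharing one core differ only in the aryl group attached to the carbon that carries a double bond to nitrogen. Compound 1 `COc1ccc(OC)c(/C=N/NC(=O)Nc2ccc(Oc3ccnc(-c4nncn4CCN(C)C)c3)c(F)c2)c1` gives 1510 nM in a functional assay on MKN-45 cells (Homo sapiens) for cytotoxicity, read by MTT assay, with a stated time of 72 h; a higher number here means a weaker inhibitor, a lower number a stronger inhibitor. Compound 2 `CN(C)CCn1cnnc1-c1cc(Oc2ccc(NC(=O)N/N=C/c3ccc(F)cc3Cl)cc2F)ccn1` gives 870 nM, and compound 3 `CN(C)CCn1cnnc1-c1cc(Oc2ccc(NC(=O)N/N=C/c3ccc(Cl)cc3)cc2F)ccn1` gives 570 nM. Compound 3 has the lowest number of the three, with a 2.6-fold lower number from compound 1 to compound 3 (0.42 log units; beyond the scatter) beyond the scatter, while a 1.5-fold lower number from compound 2 to compound 3 (0.18 log units; within the scatter) and a 1.7-fold lower number from compound 1 to compound 2 (0.24 log units; within the scatter) both lie within it.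

Compound 4 `CN(C)CCn1cnnc1-c1cc(Oc2ccc(NC(=O)N/N=C/c3ccc(O)c(O)c3)cc2F)ccn1` is not yet measured. It differs from compound 3 as follows: 3,4-dihydroxyphenyl in place of 4-chlorophenyl on a carbon with a double bond to nitrogen. Within the data shown here, no measured step introduces hydroxyl groups on this ring; the only oxygen-bearing aryl group, on compound 1, sits at the high end of the series, and the halogenated rings give the lower numbers. On that slender basis compound 4 is expected to lie above compound 3, as a 2.3-fold higher number from compound 3 to compound 4 (0.36 log units; beyond the scatter). Compound 4 is therefore estimated at 1300 nM, with a plausible range from 450 nM to 4000 nM.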

Compound 4, half-maximal inhibitory concentration: 3240 nM
Compound 4: middle estimate off by 2.5-fold (0.40 log units), on the low side; low and high end bracket the measured number.
By their numbers in this assay, from the lowest: compounds 3, 2 and 1 (each within the scatter of the next, the first and the last beyond it); then compound 4.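

Among the aryl groups on the carbon with a double bond to nitrogen, 3,4-dihydroxyphenyl gives the highest number in this assay, with a 5.7-fold higher number from compound 3 to compound 4 (0.75 log units; beyond the scatter) and a 3.7-fold higher number from compound 2 to compound 4 (0.57 log units; beyond the scatter) and also a 2.1-fold higher number from compound 1 to compound 4 (0.33 log units; beyond the scatter) all pointing the same way. The step from compound 3 to compound 4 is larger than any step among the first three compounds, so this position can move the number further than they showed, and the step from the 2,5-dimethoxyphenyl compound shows that rings carrying oxygen do not all give the same number here. Nothing measured here accounts for this rise, and no cause can be assigned to it.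

The compounds shown leave open whether a single hydroxyl group on this ring would give a number nearer to that of compound 3 or compound 4. They also leave open how an amine or a carboxylic acid on the ring would compare.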